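A few compounds are considered here, and "the series" means these few. Any claim that something is new, unique, unknown or untested is made for them only; others in the source may bear on it.

Series in a functional assay on AGS cells (Homo sapiens) for antiproliferative activity, read by MTT assay, with a stated time of 48 h; on this read-out lower numbers stand for stronger inhibition of growth and higher numbers for weaker inhibition of growth:
- Compound 1 `COc1ccccc1OCCNc1ccc(=O)n(Cc2ccc(OC)c(OC3CCCC3)c2)n1`: > 100000 nM (limit)
- Compound 2 `COc1ccc(Cn2ncc(NCCOc3ccccc3OC)c(Cl)c2=O)cc1OC`: > 100000 nM (limit)
- Compound 3 `COc1ccccc1OCCNc1ccc(=O)n(Cc2ccc(OC)c(OCC3CC3)c2)n1`: 45800 nM
- Compound 4 `COc1ccc(Cn2nc(NCCOc3ccccc3OC)ccc2=O)cc1Br`: not yet measured

Within the data shown here, compound 3 is the only compound here with a number. The entry for compound 1 is a limit of the assay. The entry for compound 2 is also a limit. Together they make up (the limit of > 100000 nM in this assay, at which 2 of the 3 values shown sit).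

The next change is bromo in place of cyclopropylmethoxy on an aromatic carbon. Among the measured compounds shown here, one measured step bears on it, an at least 2.1-fold lower number from compound 1 to compound 3 (0.33 log units; beyond the scatter). That step changes only the group on the oxygen and is a bound rather than an exact size, so it gives weak guidance. For the measured compounds named here, no measured step covers bromo. Removing the cyclopropylmethoxy group undoes what is shown for compound 3 at 45800 nM, so a small move toward weaker inhibition in this assay is expected, possibly no larger than the scatter. The expected change is a 1.4-fold higher number from compound 3 to compound 4 (0.15 log units; within the scatter). Compound 4 is estimated at 65000 nM, with an expected range of 22000 nM to 140000 nM.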

Compound 4, concentration for 50% growth inhibition: > 100000 nM
Compound 4 ended at the assay's limit; the forecaster's own chance of this, stated with the estimate: 40%; middle value at least 1.5-fold (0.18 log units) away from the limit.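

At this aromatic carbon, ortho to a methoxy group, this assay shows an at least 2.1-fold higher number from compound 3 to compound 4 (0.33 log units; beyond the scatter) for bromo in place of cyclopropylmethoxy. The earlier step changed only the group on the oxygen, whereas this change removes the oxygen as well, and among compound 1, compound 3 and compound 4 only the cyclopropylmethoxy group gives a number. Compound 4 gives a limit of the assay, > 100000 nM, and the step between compound 1 and compound 4 cannot be read: the limit of > 100000 nM in this assay, at which 3 of the 4 values shown sit.

As far as these compounds go, the full size of the loss stays open, as does whether the oxygen or the cyclopropyl ring matters more. Also open, from the compounds shown here alone, is whether an amine at this carbon, or a longer alkoxy chain, would give a lower number than compound 3.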